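Nitrophenyl shift from compound 3 to compound 4

The source may hold more compounds than are shown below. What is called first, only, known or untested is meant among the compounds shown, and "the series" means these compounds.

Measured so far in a functional assay on HeLa cells (Homo sapiens) for cytotoxicity, read by MTT assay, with a stated time of 24 h; a lower number here means a stronger inhibitor, a higher number a weaker inhibitor
- compound 1 `COc1ccc(/C=C(\C#N)C(=O)N/N=C(\C)c2c(O)c3ccc(O)cc3oc2=O)cc1OC` gives 13500 nM
- compound 2 `C/C(=N\NC(=O)/C(C#N)=C/c1ccc(Br)cc1)c1c(O)c2ccc(O)cc2oc1=O` gives 10600 nM
- compound 3 `C/C(=N\NC(=O)/C(C#N)=C/c1cccc([N+](=O)[O-])c1)c1c(O)c2ccc(O)cc2oc1=O` gives 24600 nM

Two steps place compound 3: a 1.8-fold higher number from compound 1 to compound 3 (0.26 log units; within the scatter) and a 2.3-fold higher number from compound 2 to compound 3 (0.37 log units; beyond the scatter). It therefore separates only from compound 2. Compound 4 `C/C(=N\NC(=O)/C(C#N)=C/c1ccccc1[N+](=O)[O-])c1c(O)c2ccc(O)cc2oc1=O` follows with one change, (2-nitrophenyl in place of 3-nitrophenyl on a double-bonded chain carbon bound to a double-bonded chain carbon), which puts 2-nitrophenyl in place of 3-nitrophenyl on a double-bonded chain carbon bound to a double-bonded chain carbon. Among the measured compounds shown here, no measured step moves the nitro group itself. The nearest evidence is the swaps of the whole group at this place, namely a 1.3-fold lower number from compound 1 to compound 2 (0.11 log units; within the scatter) and the two above. The largest of these is modest, so no step beyond the scatter is expected in this assay. The expected step is a 1.3-fold lower number from compound 3 to compound 4 (0.11 log units; within the scatter). Compound 4 is estimated at 19000 nM, with an expected range of 9000 nM to 40000 nM.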

Compound 4, half-maximal inhibitory concentration: 10300 nM
For compound 4 the middle estimate is 1.8-fold (0.27 log units) above the measured one, within the range that was stated.
By their numbers in this assay, from the lowest: compounds 4, 2, 1 and 3 (each within the scatter of the next, the first and the last beyond it).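

In this assay the nitro group's location on the phenyl ring matters at this place, even with the atoms unchanged (a 2.4-fold lower number from compound 3 to compound 4 (0.38 log units; beyond the scatter)). The 2-nitrophenyl group does not separate from the other two aryl groups, since both remaining steps lie within the scatter (a 1.0-fold lower number from compound 2 to compound 4 (0.01 log units; within the scatter); a 1.3-fold lower number from compound 1 to compound 4 (0.12 log units; within the scatter)). No measured evidence accounts for the shift.

Still open, from the compounds shown here alone, is whether an amine or a carboxylic acid in place of the nitro group of 2-nitrophenyl would keep the number seen for compound 4.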